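This account rests on a few compounds, and the source may have more. Where it says the series, first, only, none or still open, it means among the compounds named here.

Measured in a physicochemical assay for lipophilicity, at pH 7.4; on this read-out higher numbers stand for higher lipophilicity and lower numbers for lower lipophilicity:
- Compound 1 `CNC(=O)c1cc(C(=O)NC2CC2)cn(CC2CCCCC2)c1=O`: 4
- Compound 2 `CNC(=O)c1cc(C(=O)NC2CC2)cn(Cc2nccc3[nH]ccc23)c1=O`: 1.7
- Compound 3 `CNC(=O)c1cc(C(=O)NC2CC2)cn(Cc2cccc(OC)c2)c1=O`: 3

Compound 3 holds the second highest of these numbers. The steps that reach it are a number 1.00 log units lower from compound 1 to compound 3 (beyond the scatter) and a number 1.30 log units higher from compound 2 to compound 3 (beyond the scatter). The wider span of the series is a number 2.30 log units lower from compound 1 to compound 2 (beyond the scatter).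

Compound 4 `CNC(=O)c1cc(C(=O)NC2CC2)cn(Cc2cccc3occc23)c1=O` has not yet been measured in this assay. It carries 1-benzofuran-4-yl in place of 3-methoxyphenyl on a saturated chain carbon bound to an aromatic nitrogen. Within the data shown here, no measured step makes this exact exchange, so the guidance is indirect. The entering group shares a five-membered aromatic ring with 1 hetero atom with the group in compound 2, but its six-membered aromatic ring is of carbon only, as in compound 3. The large a number 1.30 log units higher from compound 2 to compound 3 (beyond the scatter) therefore offers only partial guidance, and a drop towards compound 2 at 1.7 is not expected. A small upward step is expected instead, estimated as a number 0.40 log units higher from compound 3 to compound 4 (beyond the scatter). For compound 4 the estimated value is 3.4, with an expected range from 3 to 3.8.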

Compound 4, distribution coefficient: 3.4
Compound 4: the middle estimate sits on the measured number at the digits printed; the measured number falls inside the stated range.
By their numbers in this assay, from the lowest: compound 2; then compound 3; then compound 4; then compound 1.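

With 1-benzofuran-4-yl in place of 3-methoxyphenyl, this assay shows a number 0.40 log units higher from compound 3 to compound 4 (beyond the scatter) and so places a fused carbon-ring group on this saturated chain carbon above the single methoxy-bearing ring. Two groups that both carry a five-membered aromatic ring with one hetero atom still stand far apart, with a number 1.70 log units higher from compound 2 to compound 4 (beyond the scatter) for a change from a group with two nitrogens to one with a single oxygen, so having two fused rings at this place does not by itself fix the number. Cyclohexyl stays on top, with a number 0.60 log units lower from compound 1 to compound 4 (beyond the scatter) at this place, and nothing at hand accounts for any of these steps.

The compounds shown leave open how a plain phenyl would stand against 3-methoxyphenyl and 1-benzofuran-4-yl. Also open, from the compounds shown here alone, is how far an amine or a carboxylic acid on the 1-benzofuran-4-yl group would move the number.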